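The source may report more compounds than this note shows. Statements on the series, on what has been measured and on what is new or still open speak of the compounds shown alone.

Measured in a functional assay on the whole organism for antagonist activity, with Mus musculus as the target; a higher number here means that more compound is needed for the effect, a lower number that less compound is needed:

- compound 1 `CC(C#CCn1ccnc1)N1CCCC1=O`: 3.7 mg/kg
- compound 2 `O=C1NCCN1CC#CCn1ccnc1`: > 100 mg/kg (a limit, not a number)

Compound 1 has a measured dose, 3.7 mg/kg, so it can be used as a numerical reference. Compound 2 stands at the limit of > 100 mg/kg in this assay, at which 1 of the 2 values shown sits. This means that its true position is not known, and no number is available as a starting point.

Compound 3 `Cc1cncn1CC#CCN1CCNC1=O` differs from compound 2 by having methyl in place of hydrogen on an aromatic carbon. Among the measured compounds shown here, no measured pair of compounds shows what this change does in this assay. With so little to go on, the expected step of an at least 1.1-fold lower number from compound 2 to compound 3 (0.04 log units; that floor lies within the scatter) is none beyond the scatter, with no direction favoured. Compound 3 may well be reported only as a limit too. If a number is obtained, the estimate for compound 3 is 90 mg/kg, within an expected range of 30 mg/kg to 250 mg/kg.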

Compound 3, dose for half-maximal effect: 66 mg/kg
Compound 3: middle estimate off by 1.4-fold (0.13 log units), on the high side; measured number inside the range.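

Methyl in place of hydrogen on an aromatic carbon, next to the ring nitrogen and next to the ring atom that bears a large group, now has a first reading in this assay: an at least 1.5-fold lower number from compound 2 to compound 3 (0.18 log units; that floor lies within the scatter). The change therefore gives this series a compound with a measured dose rather than a limit, and compound 3 can serve as a numerical reference for later changes at this position. The size of the step cannot be fixed, and it may be no more than scatter, because compound 2 is held only by a limit: the limit of > 100 mg/kg in this assay, at which 1 of the 3 values shown sits.

As far as these compounds go, whether an ethyl group or a chlorine atom at this position would act as methyl does remains open, as does the effect of methyl elsewhere on the ring. Compound 1 differs from compound 3 in more than one place, so what separates their doses cannot be assigned to any single change.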